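The source may report more compounds than this note shows. Statements on the series, on what has been measured and on what is new or still open speak of the compounds shown alone.

Of the compounds shown here, three built on one shared core have been measured so far. Compound 1 `C[C@@H](Cn1ccc(-c2ccc(C#N)c(Cl)c2)n1)NC(=O)c1ccccc1` gives 1830 nM in a functional assay on LNCaP cells (Homo sapiens) for antiproliferative activity, read by CCK-8 assay, with a stated time of 6 days; a lower number here means a stronger inhibitor, a higher number a weaker inhibitor. Compound 2 `CC(=O)c1ccc(C(=O)N[C@@H](C)Cn2ccc(-c3ccc(C#N)c(Cl)c3)n2)cc1` carries an acetyl group on an aromatic carbon where compound 1 has hydrogen, and in this assay compound 2 gives 3600 nM. Compound 3 `COc1ccc(C(=O)N[C@@H](C)Cn2ccc(-c3ccc(C#N)c(Cl)c3)n2)cc1` carries a methoxy group in place of that same hydrogen, and compound 3 gives 3410 nM. The steps between them are small: a 2.0-fold higher number from compound 1 to compound 2 (0.29 log units; within the scatter), a 1.9-fold higher number from compound 1 to compound 3 (0.27 log units; within the scatter) and a 1.1-fold lower number from compound 2 to compound 3 (0.02 log units; within the scatter). Compound 3 therefore sits among three numbers that do not separate from one another.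

Compound 4 `C[C@@H](Cn1ccc(-c2ccc(C#N)c(Cl)c2)n1)NC(=O)c1ccccc1F` differs from compound 3 in one place: 2-fluorophenyl in place of 4-methoxyphenyl on a carbonyl carbon. For the measured compounds named here, only one measured step bears on this change, the one that introduced the methoxy group, a 1.9-fold higher number from compound 1 to compound 3 (0.27 log units; within the scatter); running it backwards removes that group again. Going by the values given here, no measured compound speaks to the fluorine that enters. For compound 4 the expected step is a 1.8-fold lower number from compound 3 to compound 4 (0.25 log units; within the scatter), which stays within the scatter. Compound 4 is estimated at 1900 nM, with a range from 700 nM to 5000 nM.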

Compound 4, half-maximal inhibitory concentration: 1810 nM
Estimate against measurement, compound 4: 1.0-fold (0.02 log units) above, and the stated range covers the measured number.
By their numbers in this assay, from the lowest: compounds 4, 1, 3 and 2 (each within the scatter of the next).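

In this assay, the added fluorine gives a 1.0-fold lower number from compound 1 to compound 4 (0.00 log units; within the scatter), so compound 4, with its 2-fluorophenyl group, does not separate from the unsubstituted phenyl of compound 1. The swaps from the other two substituted compounds, a 1.9-fold lower number from compound 3 to compound 4 (0.28 log units; within the scatter) and a 2.0-fold lower number from compound 2 to compound 4 (0.30 log units; within the scatter), also stay within the scatter, so 2-fluorophenyl, 4-methoxyphenyl and 4-acetylphenyl on this carbonyl carbon cannot be told apart in these data. No measurement shown here offers an explanation for these numbers.

On these data alone, all four compounds carry a phenyl ring on this carbonyl carbon, so it remains open what a saturated ring, an amine, a carboxylic acid or a longer chain would do there. As far as these compounds go, the effect of moving the fluorine to another ring carbon also remains open, as does any change elsewhere in the shared core.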